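Spirooxindole triazole series: aryl swap on the triazole nitrogen

The compounds below may be only part of what the source reports. "The series", "measured", "known", "first", "only" and "open" are said of these compounds alone.

Measured so far in a functional assay on HepG2 cells (Homo sapiens) for antiproliferative activity, read by MTT assay, with a stated time of 48 h; a higher number here means a weaker inhibitor, a lower number a stronger inhibitor:
compound 1 `N#CC1=C(N)Oc2c(c3nc4ccccc4nc3c3ccccc23)C12C(=O)N(Cc1cnnn1-c1ccc([N+](=O)[O-])cc1)c1ccccc12` gives > 50000 nM, a limit of the assay rather than a number.
compound 2 `N#CC1=C(N)Oc2c(N)cc3nc4ccccc4nc3c2C12C(=O)N(Cc1cnnn1-c1ccc(F)cc1)c1ccccc12` gives > 50000 nM, likewise only a limit.

Compound 2 therefore stands nowhere distinct on the numbers shown: its value is a limit, and the one other value shown is a limit as well, so both results sit at the limit of > 50000 nM in this assay, at which 2 of the 2 values shown sit. Within the data shown here, no two measured compounds differ in a single place, so no measured step exists from which the size of any change in this assay could be read.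

Compound 3 `Cc1ccc(C)c(-n2nncc2CN2C(=O)C3(C(C#N)=C(N)Oc4c(N)cc5nc6ccccc6nc5c43)c3ccccc32)c1` differs from compound 2 in one place: 2,5-dimethylphenyl in place of 4-fluorophenyl on an aromatic nitrogen. With no measured step to lean on, the expectation for this assay rests only on the two limits shown. The step from compound 2 to compound 3 is expected to be none beyond the usual scatter, as a step that the limit leaves unreadable from compound 2 to compound 3. Compound 3 is estimated at 70000 nM, within 20000 nM to 250000 nM, with a strong chance that this assay again reports only a limit.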

Compound 3, half-maximal inhibitory concentration: > 50000 nM
Compound 3 ended at the assay's limit; the forecaster's own chance of this, stated with the estimate: 80%; the middle value lies beyond the limit too.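

In this assay compound 3 gives > 50000 nM, a limit and not a number. Among these compounds, no step from compound 2 to compound 3 can therefore be read, as all the results shown sit at one limit: the limit of > 50000 nM in this assay, at which 3 of the 3 values shown sit. The compounds shown leave open whether any aryl group on this aromatic nitrogen, or any change to the shared core, would give a measurable value in this assay.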